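Swapping a hydroxyethyl for tert-butyl on a weak inhibitor

A few compounds are considered here, and "the series" means these few. Any claim that something is new, unique, unknown or untested is made for them only; others in the source may bear on it.

Compound 1 `O=c1cc(Cn2cc(CCO)nn2)c2ccc(O)cc2o1` gives 90300 nM in a functional assay on A549 cells (Homo sapiens) for inhibition, read by MTT assay, with a stated time of 72 h; a lower number here means a stronger inhibitor, a higher number a weaker inhibitor.
Compound 3 `O=c1cc(Cn2cc(CCCO)nn2)c2ccc(O)cc2o1` gives 96200 nM in this assay.
Compound 2 `CC(O)c1cn(Cc2cc(=O)oc3cc(O)ccc23)nn1` gives > 100000 nM in this assay, which is a limit of the assay and not a number.

Compound 2 therefore stands at the limit of > 100000 nM in this assay, at which 1 of the 3 values shown sits, and on the numbers shown it sits beside the other two rather than apart from them. All three measured steps are small: an at least 1.1-fold higher number from compound 1 to compound 2 (0.04 log units; that floor lies within the scatter); an at least 1.0-fold lower number from compound 2 to compound 3 (0.01 log units; that floor lies within the scatter); a 1.1-fold higher number from compound 1 to compound 3 (0.03 log units; within the scatter). Changing the small side group on the five-membered ring has so far moved nothing beyond the scatter.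

Compound 4 `CC(C)(C)c1cn(Cc2cc(=O)oc3cc(O)ccc23)nn1` differs from compound 2 by tert-butyl in place of 1-hydroxyethyl on an aromatic carbon. Since every comparable change among compounds 1, 2 and 3 stayed within the scatter, no step beyond the scatter is expected in this assay here either, in either direction. Compound 4 is expected to give about 100000 nM, within 50000 nM to 200000 nM, in this assay. The expected step is a number no higher from compound 2 to compound 4 (the limit leaves the size open), and a result reported only as a limit is considered likely.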

Compound 4, half-maximal inhibitory concentration: 67600 nM
Compound 4: the middle estimate sits 1.5-fold (0.17 log units) above what was measured, and the stated range covers the measured number.
By their numbers in this assay, from the lowest: compounds 4, 1 and 3 (each within the scatter of the next). At a limit, above all of these: compound 2.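

On this position of the five-membered ring, a side chain carrying a hydroxy group can give way to tert-butyl, with no hydrogen-bond donor or acceptor, without leaving the scatter in this assay: there is a 1.4-fold lower number from compound 3 to compound 4 (0.15 log units; within the scatter), and a 1.3-fold lower number from compound 1 to compound 4 (0.13 log units; within the scatter). Against compound 2 only a floor can be read, namely an at least 1.4-fold lower number from compound 2 to compound 4 (0.17 log units; that floor lies within the scatter). Compound 2 stands at a limit of the assay and not at a number: the limit of > 100000 nM in this assay, at which 1 of the 4 values shown sits.

From the compounds shown here alone, whether an amine, a carboxylic acid or a phenyl ring at this position would move the number beyond the scatter remains open. No step among these four compounds goes beyond the scatter, so they do not show whether this position can change the number at all, or what a change elsewhere on the shared core would do.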